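The source may report more compounds than this note shows. Statements on the series, on what has been measured and on what is new or still open speak of the compounds shown alone.

Measured compounds and their values:

- Compound 1, `CN1CCC(c2c[nH]c3cc(Nc4ccc(F)c(F)c4)ccc23)CC1`: 91%
- Compound 2, `c1cc2c(C3CCNCC3)c[nH]c2cc1Nc1ccc2c(C3CCNCC3)c[nH]c2c1`: 89%
- Compound 3, `N#Cc1c[nH]c2nc(Nc3ccc4c(C5CCNCC5)c[nH]c4c3)ccc12`: 100%

These three compounds were tested in an ADME assay on microsomes from liver (Homo sapiens) for metabolic stability, with a stated time of 1 h; a higher number here means that more of the compound is left, a lower number that less of the compound is left. In this assay compound 1 gives 91%, compound 2 gives 89% and compound 3 gives 100%. Compound 1 lies in the middle of the three numbers, and both its neighbours sit within the usual scatter of it: the gap to compound 2 and the gap to compound 3 are each too small to count as a real difference. All three compounds therefore look much alike here, with most of each compound still present after the stated time.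

The compound not yet measured is compound 4, `Fc1ccc(Nc2ccc3c(C4CCNCC4)c[nH]c3c2)cc1F`. It differs from compound 1 in one place: hydrogen in place of methyl on an amine nitrogen in a ring. After the change, the ring carries 1-methylpiperidin-4-yl no longer but piperidin-4-yl, the same group that is found in compound 2 and compound 3. Because compound 2 gives 89% and compound 3 gives 100% in this assay, both with this group, the step of a number 2 percentage points higher from compound 1 to compound 4 (within the scatter) is expected to stay within the scatter, with no clear direction. Compound 4 is estimated at 93%, in a range from 80% to 100%.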

Compound 4, percent of the compound remaining in the liver assay: 89%
Compound 4: the middle estimate sits 4 percentage points above what was measured, within the range that was stated.
By their numbers in the liver assay, from the lowest: compounds 2, 4, 1 and 3 (each within the scatter of the next, the first and the last beyond it).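

Going by these compounds alone, in the liver assay, hydrogen in place of methyl on the amine nitrogen in the ring gives a number 2 percentage points lower from compound 1 to compound 4 (within the scatter), so this pair offers the first direct reading at this position: here the nitrogen carries either group with no real difference in how much compound is left. The same holds in a second property, since in a physicochemical assay for solubility, in phosphate buffer, at pH 7.4 (a higher number here means a more soluble compound, a lower number a less soluble compound), compound 1 gives 200000 nM and compound 4 gives 178000 nM, two values within the usual scatter of each other. Nothing available here gives a measured reason why this change leaves both read-outs so close.

Within the data shown here, whether the nitrogen would tolerate something larger than methyl, such as an ethyl group, an acetyl group or a longer chain ending in an alcohol, stays open, as a single pair shows only the step from methyl to hydrogen. It is also open whether the same step would be as small on other cores, such as those of compound 2 and compound 3, which carry piperidin-4-yl but have no 1-methylpiperidin-4-yl partner among the compounds shown.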